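Adding a Methyl to Compound 2: An Expectation

A few compounds are considered here, and "the series" means these few. Any claim that something is new, unique, unknown or untested is made for them only; others in the source may bear on it.

What has been measured so far in a functional assay on CHO cells for agonist activity at Alpha-1A adrenergic receptor (Homo sapiens), read by FLIPR and calcium flux; on this read-out lower numbers stand for an effect already at smaller amounts and higher numbers for an effect only at larger amounts of compound:
Compound 1 `COc1c(C)ccc2c1CCC2c1ncc[nH]1` gives 167 nM.
Compound 2 `CS(=O)(=O)Nc1cccc2c1CCC2c1ncc[nH]1` gives 70 nM.
Compound 3 `Cc1oncc1-c1cccc2c1CCC2c1ncc[nH]1` gives 111 nM.

Compound 2 holds the lowest of the three numbers, although compound 3 sits close to it: the step from compound 2 to compound 3 is a 1.6-fold higher number from compound 2 to compound 3 (0.20 log units; within the scatter), so the two cannot be told apart. Compound 1 lies further off, and its distance from compound 2 is beyond the scatter.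

Compound 4 `Cc1ccc2c(c1NS(C)(=O)=O)CCC2c1ncc[nH]1` has not yet been measured. It differs from compound 2 in one place: methyl in place of hydrogen on an aromatic carbon. Going by the values given here, no measured step speaks to this spot. Among the compounds with values here, the only step in hand, from compound 2 to compound 3, exchanges the methanesulfonamido group itself for a ring and stays within the scatter. Compound 1 carries a methyl on a ring of the same kind together with a methoxy, but it has no partner without the methyl, so it says nothing about a methyl on its own. With nothing pointing either way, the expected step from compound 2 to compound 4 is a 1.1-fold higher number from compound 2 to compound 4 (0.06 log units; within the scatter), that is, none beyond the scatter. The estimate for compound 4 in this assay is therefore 80 nM, with a range from 30 nM to 220 nM.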

Compound 4, half-maximal effective concentration: 33 nM
The estimate for compound 4 lay 2.4-fold (0.38 log units) above the measured number; the range from low to high includes it.
By their numbers in this assay, from the lowest: compound 4; then compounds 2, 3 and 1 (each within the scatter of the next, the first and the last beyond it).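

In this assay the aromatic carbon ortho to the methanesulfonamido group now has a measured step of its own: methyl in place of hydrogen gives a 2.1-fold lower number from compound 2 to compound 4 (0.33 log units; beyond the scatter) and so shows that one added carbon at this spot can move the number further than repeated measurements scatter, something the earlier step that exchanged the whole methanesulfonamido group could not show. Compound 1 also gains its first partner differing in one place, as methanesulfonamido in place of methoxy on an aromatic carbon gives a 5.1-fold lower number from compound 1 to compound 4 (0.70 log units; beyond the scatter) with the methyl present in both compounds. No measured property or other outside information accompanies these numbers, so what lies behind either step remains unexplained.

The compounds shown leave open whether another small group at this spot, such as an ethyl chain, a chlorine atom or an amine, would shift the number in the same direction as methyl. They also leave open whether the same methyl would give a similar step with 5-methyl-1,2-oxazol-4-yl in place of methanesulfonamido.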